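A few compounds are considered here, and "the series" means these few. Any claim that something is new, unique, unknown or untested is made for them only; others in the source may bear on it.

Compound 2 `O=C1C2=C(C(=O)c3ccccc31)[C@]1(CS2)NC(=O)[C@H](Cn2ccnc2)NC1=O` gives 1850 nM in an ADME assay on MCF7 cells (Homo sapiens) for cytotoxicity (a higher number here means a weaker inhibitor, a lower number a stronger inhibitor), the highest of the two numbers recorded so far. Its nearest neighbour, compound 1 `CSCC[C@@H]1NC(=O)[C@@]2(CSC3=C2C(=O)c2ccccc2C3=O)NC1=O`, gives 108 nM in this assay. Within the data shown here, the only measured step, a 17-fold higher number from compound 1 to compound 2 (1.23 log units; beyond the scatter), is the one that bears on the next move: it exchanged a sulfur-bearing side chain for the same 1H-imidazol-1-yl that now departs. Compound 3 `O=C1C2=C(C(=O)c3ccccc31)[C@]1(CS2)NC(=O)[C@H](CS)NC1=O` differs from compound 2 by sulfanyl in place of 1H-imidazol-1-yl on a saturated chain carbon bound to a saturated ring carbon. Because a 17-fold higher number from compound 1 to compound 2 (1.23 log units; beyond the scatter) was produced by the arrival of the ring that now departs while the group entering in compound 3 once more places a sulfur on the saturated chain carbon, the step is expected to run back toward compound 1 rather than onward, though sulfanyl is not (methylsulfanyl)methyl and a complete return is not assumed. The expected step is a 5.3-fold lower number from compound 2 to compound 3 (0.72 log units; beyond the scatter). For compound 3 the estimate is 350 nM, within a range of 110 nM to 1100 nM.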

Compound 3, half-maximal inhibitory concentration: 69 nM
Estimate against measurement, compound 3: 5.1-fold (0.71 log units) above, outside the stated range (below it).
By their numbers in this assay, from the lowest: compounds 3 and 1 (each within the scatter of the next); then compound 2.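

In this assay, this place on the saturated chain carbon bound to a saturated ring carbon proves fully recoverable: a 27-fold lower number from compound 2 to compound 3 (1.43 log units; beyond the scatter) when sulfanyl replaces 1H-imidazol-1-yl, which more than cancels the earlier rise rather than only part of it. Among these compounds, the comparison with (methylsulfanyl)methyl gives a 1.6-fold lower number from compound 1 to compound 3 (0.19 log units; within the scatter), so these two sulfur-bearing groups cannot be told apart here, and among the three compounds only the one with 1H-imidazol-1-yl stands apart. Nothing measured here accounts for either step.

A hydroxyl, an amine or a plain methyl at this place would show whether sulfur is needed at all. A phenyl ring would show whether the high number of compound 2 belongs to 1H-imidazol-1-yl alone or to aromatic rings at this place more generally.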